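A few compounds are considered here, and "the series" means these few. Any claim that something is new, unique, unknown or untested is made for them only; others in the source may bear on it.

Measured so far in an assay for inhibition of Amine oxidase [flavin-containing] B (Bos taurus), read by fluorescence, with a stated time of 30 min; a lower number here means a stronger inhibitor, a higher number a weaker inhibitor:
compound 1, `Cc1cc(=O)oc2cc(OCC(=O)NN)ccc12`, gives 874 nM
compound 2, `Cc1cc(=O)oc2cc(OCc3nnc(S)o3)ccc12`, gives 918 nM

Compound 2 stands alongside compound 1 on these numbers: the step of a 1.1-fold higher number from compound 1 to compound 2 (0.02 log units; within the scatter) lies within the scatter, so the two cannot be told apart in this assay. Compound 3, `Cc1cc(=O)oc2cc(OCc3nnc(S)s3)ccc12`, is not yet measured. It differs from compound 2 in one place: 5-sulfanyl-1,3,4-thiadiazol-2-yl in place of 5-sulfanyl-1,3,4-oxadiazol-2-yl on a saturated chain carbon bound to an oxygen on an aromatic ring. Going by the values given here, no measured step shows this exact exchange. Among the compounds with values here, the only step available, a 1.1-fold higher number from compound 1 to compound 2 (0.02 log units; within the scatter), replaced the whole group on that chain carbon with a different ring and left the number essentially unchanged, which gives no sign that this part of the molecule moves the assay much. Exchanging one ring atom for another within the same kind of ring is a smaller change still, so the expected step of a 1.0-fold lower number from compound 2 to compound 3 (0.01 log units; within the scatter) is none beyond the scatter. Compound 3 is therefore estimated at 900 nM, with a range from 300 nM to 2700 nM.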

Compound 3, inhibition constant: 896 nM
The estimate for compound 3 lay 1.0-fold (0.00 log units) above the measured number; the range from low to high includes it.
By their numbers in this assay, from the lowest: compounds 1, 3 and 2 (each within the scatter of the next).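

In this assay, putting 5-sulfanyl-1,3,4-thiadiazol-2-yl in place of 5-sulfanyl-1,3,4-oxadiazol-2-yl gives a 1.0-fold lower number from compound 2 to compound 3 (0.01 log units; within the scatter) and so exchanging this one ring atom, an oxygen for a sulfur, leaves the two compounds indistinguishable. The new group also cannot be told apart from the aminocarbamoyl of compound 1, with a 1.0-fold higher number from compound 1 to compound 3 (0.01 log units; within the scatter) and so three different groups on this saturated chain carbon now give matching numbers, where previously only two could be compared. No measurement on these compounds accounts for this lack of difference.

Still open, from the compounds shown here alone, is whether a carboxylic acid or an amine on that saturated chain carbon, or a longer chain carrying these same groups, would move the number beyond the scatter. Going by these compounds, whether changes to the shared core would do so also remains unknown.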